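Nitro to amino at the assay limit

The source may report more compounds than this note shows. Statements on the series, on what has been measured and on what is new or still open speak of the compounds shown alone.

Of the compounds shown here, three have been tested so far, and none gives a number. In a functional assay on HCT-15 cells (Homo sapiens) for antiproliferative activity, read by MTT assay, with a stated time of 72 h (on this read-out lower numbers stand for stronger inhibition and higher numbers for weaker inhibition), compound 1 (`COc1cc(-c2nccn2C)cc(OC)c1OC`) gives > 100000 nM as a limit of the assay and not a number. Compound 2 (`COc1cc(OC)cc(-n2ccnc2-c2cc(OC)c(OC)c(OC)c2)c1`) likewise gives > 100000 nM as a limit and not a number. Compound 3 (`COc1ccc(OC(=O)c2cc(OC)c(OC)c(OC)c2)cc1[N+](=O)[O-]`) also gives > 100000 nM as a limit and not a number. The picture so far is the limit of > 100000 nM in this assay, at which 3 of the 3 values shown sit, and no order among the three can be read from it. Compound 3 therefore offers only a limit as the starting point for the next step.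

Compound 4 (`COc1ccc(OC(=O)c2cc(OC)c(OC)c(OC)c2)cc1N`) differs from compound 3 by amino in place of nitro on an aromatic carbon and the change is amino in place of nitro on an aromatic carbon, ortho to a methoxy group. Going by the values given here, no measured pair shows what this replacement does, so the expectation rests on the structural change alone and stays loose. A shift towards stronger inhibition is expected, with an at least 10-fold lower number from compound 3 to compound 4 (1.00 log units; beyond the scatter) as the estimated step, although a second result at the limit remains possible. In this assay the expected value for compound 4 is 10000 nM with an estimated range of 500 nM to 100000 nM at this stage.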

Compound 4, half-maximal inhibitory concentration: > 100000 nM
Compound 4 gave a limit, no number; the forecaster's own chance of this, stated with the estimate: 35%; middle value at least 10-fold (1.00 log units) away from the limit.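

In this assay, compound 3 and compound 4 each give a limit and not a number, so the replacement of nitro by amino yields no readable step between them: the limit of > 100000 nM in this assay, at which 4 of the 4 values shown sit. The compounds shown leave open whether this replacement changes inhibition at all, and which structural change would give a value inside the range of this assay.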